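Pyrazole ureas: dropping one trifluoromethyl at the urea end

The compounds below may be only part of what the source reports. "The series", "measured", "known", "first", "only" and "open" are said of these compounds alone.

Among the measured compounds shown here, compound 2 `COc1cc(-c2nn(-c3cccc(NC(=O)Nc4cc(C(F)(F)F)cc(C(F)(F)F)c4)c3)cc2-c2ccncc2)ccc1Cl` stands lowest of the three numbers so far in a functional assay on HOP-62 cells (Homo sapiens) for inhibition, read by sulforhodamine B assay, with a stated time of 48 h (on this read-out lower numbers stand for stronger inhibition of growth and higher numbers for weaker inhibition of growth), where compound 2 gives 855 nM. Compound 3 `O=C(Nc1cccc(-n2cc(-c3ccncc3)c(-c3ccc(Cl)c(O)c3)n2)c1)Nc1ccc(Cl)c(Cl)c1` gives 2080 nM and compound 1 `O=C(Nc1cccc(-n2cc(-c3ccncc3)c(-c3ccc(Cl)c(O)c3)n2)c1)Nc1cccc(C(F)(F)F)c1` gives 6860 nM. For the measured compounds named here, the one step on record, a 3.3-fold lower number from compound 1 to compound 3 (0.52 log units; beyond the scatter), concerns a change of the whole terminal ring and bears only loosely on the present question.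

Compound 4 `COc1cc(-c2nn(-c3cccc(NC(=O)Nc4cccc(C(F)(F)F)c4)c3)cc2-c2ccncc2)ccc1Cl` is reached from compound 2 by hydrogen in place of trifluoromethyl on an aromatic carbon. Going by the values given here, no measured pair isolates this change. Compound 1 carries a single trifluoromethyl at the urea terminus, as compound 4 does, but differs from compound 4 in hydroxy versus methoxy on the core aryl, so its value in this assay only suggests the direction. Because compound 1 gives 6860 nM while compound 2 gives 855 nM, the number for compound 4 is expected to rise, with an expected step of a 2.9-fold higher number from compound 2 to compound 4 (0.47 log units; beyond the scatter). Compound 4 is therefore estimated at 2500 nM, in a range of 900 nM to 7000 nM.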

Compound 4, concentration for 50% growth inhibition: 1340 nM
Compound 4: the middle estimate sits 1.9-fold (0.27 log units) above what was measured; measured number inside the range.
By their numbers in this assay, from the lowest: compounds 2, 4 and 3 (each within the scatter of the next, the first and the last beyond it); then compound 1.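

In this assay, hydrogen in place of trifluoromethyl on an aromatic carbon gives a 1.6-fold higher number from compound 2 to compound 4 (0.20 log units; within the scatter), so at this place on the terminal ring, a second trifluoromethyl makes no difference that the read-out can resolve. Methyl in place of hydrogen on the oxygen of the core aryl gives a 5.1-fold lower number from compound 1 to compound 4 (0.71 log units; beyond the scatter), and of the two new steps only this one, at the other end of the molecule, lies beyond the scatter. No available evidence accounts for either step.

On these data alone, whether an amine or a carboxylic acid on this aromatic carbon would stay within the scatter of compound 4 remains open. Also open, as far as these compounds go, is whether a longer chain on the core oxygen would extend or reverse the step seen with methyl.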